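A few compounds are considered here, and "the series" means these few. Any claim that something is new, unique, unknown or untested is made for them only; others in the source may bear on it.

Measured so far in a functional assay on PANC-1 cells (Homo sapiens) for cytotoxicity, read by MTT assay, with a stated time of 72 h, tested at 1 uM; on this read-out lower numbers stand for a stronger effect and higher numbers for a weaker effect at the one concentration tested:
compound 1 `C=C1C(=O)O[C@@H](c2ccccc2)[C@H]1C` gives 143%
compound 2 `C=C1C(=O)O[C@@H](c2ccc(OC)cc2)[C@H]1C` gives 130%

Among the compounds with values here, compound 1 stands highest of the two numbers; its only neighbour is compound 2, reached by a number 13 percentage points lower from compound 1 to compound 2 (beyond the scatter) through methoxy in place of hydrogen on an aromatic carbon. Compound 3 `C=C1C(=O)O[C@@H](c2ccccc2)[C@H]1c1ccccc1` differs from compound 1 by phenyl in place of methyl on a saturated ring carbon, two ring bonds from the ring oxygen. Within the data shown here, no measured step touches that saturated ring carbon, and the step from the aromatic carbon does not bear on it, so no size or direction is expected beyond the scatter. Compound 3 is expected to give 130%, between 85% and 165%. The expected step is a number 13 percentage points lower from compound 1 to compound 3 (beyond the scatter).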

Compound 3, a percentage reported as activity, at one concentration (the size of the read-out at that concentration, not a potency): 108%
For compound 3 the middle estimate is 22 percentage points above the measured one; measured number inside the range.
By their numbers in this assay, from the lowest: compound 3; then compound 2; then compound 1.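

In this assay the saturated ring carbon, two ring bonds from the ring oxygen, is shown for the first time to affect the read-out: phenyl in place of methyl gives a number 35 percentage points lower from compound 1 to compound 3 (beyond the scatter) and so moves it towards a stronger effect. Within the data shown here, this change at a site no earlier step had touched has a large effect. No available evidence accounts for this shift.

The compounds shown leave open whether the aromatic ring itself matters at this carbon. An ethyl group, a cyclohexyl ring or an amine there would help to settle that question.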